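A Fluoro-to-Hydroxy Swap in a Flat Series

The source may report more compounds than this note shows. Statements on the series, on what has been measured and on what is new or still open speak of the compounds shown alone.

Three compounds share one core and differ only in a single group on an aromatic ring. In a functional assay on cells (Erythrocyte, Rattus norvegicus) for inhibition, read by hemolysis, with a stated time of 1 h (on this read-out lower numbers stand for stronger inhibition and higher numbers for weaker inhibition), compound 1 `COc1ccc(C(=O)/C=C/c2cc(OC)c(OC)cc2OC)cc1` gives 2.18 ug/mL, compound 2 `COc1cc(OC)c(OC)cc1/C=C/C(=O)c1ccc(C)cc1` gives 2.24 ug/mL, and compound 3 `COc1cc(OC)c(OC)cc1/C=C/C(=O)c1ccc(F)cc1` gives 2.22 ug/mL. Compound 3 therefore lies within the usual scatter of both others.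

The next structure, compound 4 `COc1cc(OC)c(OC)cc1/C=C/C(=O)c1ccc(O)cc1`, has one further swap: hydroxy in place of fluoro on an aromatic carbon. This places hydroxy in place of fluoro on an aromatic carbon.

Going by the values given here, three measured steps bear on this swap. Methyl in place of methoxy gave a 1.0-fold higher number from compound 1 to compound 2 (0.01 log units; within the scatter), fluoro in place of methoxy gave a 1.0-fold higher number from compound 1 to compound 3 (0.01 log units; within the scatter), and fluoro in place of methyl gave a 1.0-fold lower number from compound 2 to compound 3 (0.00 log units; within the scatter). All three stayed within the scatter, so no clear shift in either direction is expected in this assay. Among the compounds with values here, none of the measured compounds carries a hydroxy group, however, so the range is kept wide. The expected result is a 1.0-fold lower number from compound 3 to compound 4 (0.00 log units; within the scatter). For compound 4 the estimate is 2.2 ug/mL, with an expected range of 1.3 ug/mL to 3.7 ug/mL.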

Compound 4, half-maximal inhibitory concentration: 2.29 ug/mL
Compound 4: middle estimate off by 1.0-fold (0.02 log units), on the low side, within the range that was stated.
By their numbers in this assay, from the lowest: compounds 1, 3, 2 and 4 (each within the scatter of the next).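

Hydroxy brings a hydrogen-bond donor to this position on the ring, something fluoro lacks, yet the result in the hemolysis test (this assay) stays within the scatter (a 1.0-fold higher number from compound 3 to compound 4 (0.01 log units; within the scatter)). Hydroxy in place of methyl gives the same picture (a 1.0-fold higher number from compound 2 to compound 4 (0.01 log units; within the scatter)), as does hydrogen in place of methyl on the oxygen of the methoxy group (a 1.1-fold higher number from compound 1 to compound 4 (0.02 log units; within the scatter)). Methoxy, methyl, fluoro and hydroxy at this position therefore cannot be told apart by this read-out, so the flat picture now extends to a group with a hydrogen on oxygen.

On these data alone, whether an amine or a carboxylic acid at this position would also stay within the scatter remains open. Nothing at hand explains why these four groups cannot be told apart.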